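The source may hold more compounds than are shown below. What is called first, only, known or untested is meant among the compounds shown, and "the series" means these compounds.

Measured compounds:
- compound 1, `COc1nc(C)c(Nc2nc(Cl)cn([C@H](COC(=O)c3cccnc3)C3CC3)c2=O)cc1C`: in an assay on frontal cortex for displacement of a labelled ligand from corticotropin-releasing factor receptor 1 (Rattus norvegicus), with a stated time of 2 h (a lower number here means a stronger inhibitor, a higher number a weaker inhibitor), compound 1 gives 5.2 nM
- compound 2, `COc1nc(C)c(Nc2nc(Cl)cn([C@H](COC(=O)Nc3ccc(Cl)cc3Cl)C3CC3)c2=O)cc1C`: in this assay compound 2 gives 1.7 nM

Going by the values given here, compound 2 holds the lowest of the two numbers measured so far; the only other point is compound 1, and the step of a 3.1-fold lower number from compound 1 to compound 2 (0.49 log units; beyond the scatter) separates them. Compound 3, `COc1nc(C)c(Nc2nc(Cl)cn([C@H](COC(=O)Nc3cccnc3)C3CC3)c2=O)cc1C`, differs from compound 2 in one place: pyridin-3-yl in place of 2,4-dichlorophenyl on an amide-type nitrogen. Among the compounds with values here, no measured step bears directly on this change. Within the data shown here, the one step available, a 3.1-fold lower number from compound 1 to compound 2 (0.49 log units; beyond the scatter), swapped pyridin-3-yl for (2,4-dichlorophenyl)amino on the carbonyl carbon, so it mixed the change of the ring with a change of the link, and its size cannot be assigned to the ring alone. Since compound 3 keeps the carbamate link of compound 2 but takes the pyridin-3-yl ring of compound 1, the expected outcome in this assay lies between the two measured numbers, a step of a 2.1-fold higher number from compound 2 to compound 3 (0.31 log units; beyond the scatter) toward a higher number. Compound 3 is therefore estimated at 3.5 nM, within 1.3 nM to 10 nM.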

Compound 3, half-maximal inhibitory concentration: 10 nM
Beside the measured number, compound 3's estimate is 2.9-fold (0.46 log units) below it; low and high end bracket the measured number.
By their numbers in this assay, from the lowest: compound 2; then compounds 1 and 3 (each within the scatter of the next).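

With the carbamate link held fixed, the ring on the amide-type nitrogen can now be read on its own: in this assay, 2,4-dichlorophenyl gives way to pyridin-3-yl with a 5.9-fold higher number from compound 2 to compound 3 (0.77 log units; beyond the scatter). With pyridin-3-yl held fixed, the added amino link gives a 1.9-fold higher number from compound 1 to compound 3 (0.28 log units; within the scatter), so that pair cannot be told apart in this assay, and of the two changes mixed in the earlier step only the ring change has so far been shown beyond the scatter. No outside data bear on why the ring matters at this position.

On these data alone, it remains open whether the chlorines or the ring nitrogen carries the step, a question that an unsubstituted phenyl ring on the same nitrogen would address. Also open, as far as these compounds go, is how a single chlorine, or a methoxy group, on that phenyl ring would read.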